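Methoxy in place of hydrogen on compound 2

The compounds below may be only part of what the source reports. "The series", "measured", "known", "first", "only" and "open" are said of these compounds alone.

In a functional assay on A549 cells (Homo sapiens) for cytotoxicity, read by MTT assay, with a stated time of 6 days (on this read-out lower numbers stand for an effect already at smaller amounts and higher numbers for an effect only at larger amounts of compound), compound 1 (`COC(=O)c1c(-c2ccc([N+](=O)[O-])cc2)oc2cc(OC)ccc2c1=O`) gives > 25 ug/mL as a limit of the assay and not a number. Compound 2 (`O=C(O)c1c(-c2ccc([N+](=O)[O-])cc2)oc2ccccc2c1=O`) gives > 25 ug/mL in the same way, so it stands at a limit with no number of its own. The record so far is the limit of > 25 ug/mL in this assay, at which 2 of the 2 values shown sit, and holds no measured number. Compound 3 (`COc1ccc2c(=O)c(C(=O)O)c(-c3ccc([N+](=O)[O-])cc3)oc2c1`) carries methoxy in place of hydrogen on an aromatic carbon of compound 2, and methoxy in place of hydrogen on an aromatic carbon is the whole change. For the measured compounds named here, no measured step gives a size for this change, so no shift beyond the scatter is expected in either direction in this assay and another limit is the likeliest report. That expectation rests on compound 2 with its limit of > 25 ug/mL alone. The estimated step is a step that the limit leaves unreadable from compound 2 to compound 3 and is expected to stay within the scatter. The estimate for compound 3 is 35 ug/mL with an expected range from 18 ug/mL to 70 ug/mL if a number is reported at all.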

Compound 3, concentration for half-maximal effect: > 25 ug/mL
Compound 3: a limit, no number; the forecaster's own chance of this, stated with the estimate: 85%; the middle value lies beyond the limit too.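

In this assay no step can be read among compound 1, compound 2 and compound 3, which share one limit and no number: the limit of > 25 ug/mL in this assay, at which 3 of the 3 values shown sit. The compounds shown leave open whether any change on the shared core gives a measured number, and what size the methoxy or methyl change has.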